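A few compounds are considered here, and "the series" means these few. Any claim that something is new, unique, unknown or untested is made for them only; others in the source may bear on it.

Of the compounds shown here, three have been measured in a functional assay on CCRF-CEM cells (Homo sapiens) for cytotoxicity, read by MTT assay, with a stated time of 72 h (on this read-out higher numbers stand for weaker inhibition of growth and lower numbers for stronger inhibition of growth), and a fourth waits. Compound 3 `CSc1nc(NCc2ccccc2)c2cccnc2n1` gives 56300 nM. Compound 2 `CSc1nc(NCc2ccccc2)c2ccccc2n1` shares the same kind of substituent on a different core and gives 87900 nM; the difference between the two cores is not broken down here, and the two values lie within the usual scatter of each other. Compound 1 `CSc1nc(NCCCCCO)c2cccnc2n1` reaches only a limit of this assay, > 100000 nM, and no number beyond it. Compound 1 arises from compound 3 by one change, (4-hydroxybutyl in place of phenyl on a saturated chain carbon bound to a nitrogen on an aromatic ring), and that change made a step of an at least 1.7-fold higher number from compound 3 to compound 1 (0.24 log units; that floor lies within the scatter), a floor set because compound 1 sits at the limit of > 100000 nM in this assay, at which 1 of the 3 values shown sits.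

Compound 4 `CSc1nc(NCCCCCO)c2ccccc2n1` is not yet measured. It arises from compound 2 by the same change, (4-hydroxybutyl in place of phenyl on a saturated chain carbon bound to a nitrogen on an aromatic ring), made on the other core. Since compound 2 already starts from 87900 nM, the step from compound 2 to compound 4 is expected to be about a 1.8-fold higher number from compound 2 to compound 4 (0.26 log units; within the scatter), resting on the step seen from compound 3 to compound 1. Compound 4 is therefore estimated to give about 160000 nM, within a range of 70000 nM to 400000 nM, in this assay.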

Compound 4, concentration for 50% growth inhibition: > 100000 nM
Compound 4: only a limit was reported (the forecaster's own chance of this, stated with the estimate: 70%); the middle value lies beyond the limit too.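

In this assay compound 4 gives > 100000 nM, which is a limit of the assay and not a number. Putting 4-hydroxybutyl in place of phenyl therefore yields only a floor, an at least 1.1-fold higher number from compound 2 to compound 4 (0.05 log units; that floor lies within the scatter), so these data do not show that the change weakens growth inhibition on this core, nor how large the true step is. Both cores end at the same limit after the change, which fits the change carrying over from one core to the other but does not prove it, and the size of its effect cannot be compared: the same change on two cores in this assay, an at least 1.7-fold higher number (0.24 log units; that floor lies within the scatter) from compound 3 to compound 1 and an at least 1.1-fold higher number (0.05 log units; that floor lies within the scatter) from compound 2 to compound 4; the limit leaves it open whether they differ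

The compounds shown leave open how far beyond the limit the two 4-hydroxybutyl compounds lie, and so whether the two cores respond alike: the limit of > 100000 nM in this assay, at which 2 of the 4 values shown sit. Also open is whether another group in the same place, such as a chain ending in an amine or a carboxylic acid, would give a real number in this assay.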